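The compounds below may be only part of what the source reports. "The series", "measured", "known", "first", "only" and "open" are said of these compounds alone.

For the measured compounds named here, in a functional assay on MCF7 cells (Homo sapiens) for inhibition, read by CCK-8 assay, with a stated time of 48 h (on this read-out higher numbers stand for weaker inhibition of growth and lower numbers for stronger inhibition of growth), compound 2 `COc1ccc(CNc2nc(Nc3ccc(N4CCN(C)CC4)cn3)ncc2Cl)cc1` gives 17300 nM, the only full number in this small set. Compound 1 `Cc1ccccc1Nc1nc(NC2CCCCC2)ncc1Cl` gives only a limit of the assay, > 100000 nM. Compound 3 `Cc1cc(C)c(Nc2nc(Nc3ccc(N4CCN(C)CC4)cn3)ncc2Cl)c(C)c1` differs from compound 2 in one place: 2,4,6-trimethylphenyl in place of 4-methoxybenzyl on a nitrogen on an aromatic ring. Going by the values given here, no measured pair here shows what such a change does, so the expectation rests on compound 2 alone, while compound 1 sits at the limit of > 100000 nM in this assay, at which 1 of the 2 values shown sits. The expected step of a 1.4-fold higher number from compound 2 to compound 3 (0.16 log units; within the scatter) is small, within the usual scatter, with a slight lean toward weaker growth inhibition. Compound 3 is therefore estimated at 25000 nM, with a range from 5000 nM to 100000 nM.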

Compound 3, concentration for 50% growth inhibition: 9470 nM
The estimate for compound 3 lay 2.6-fold (0.42 log units) above the measured number, and the stated range covers the measured number.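

In this assay, for the compounds shown here, this change gives a 1.8-fold lower number from compound 2 to compound 3 (0.26 log units; within the scatter), the first step that can be read at this position. On this nitrogen, 2,4,6-trimethylphenyl and 4-methoxybenzyl therefore cannot be told apart, even though the oxygen of 4-methoxybenzyl is absent from the group that enters. Nothing shown here explains this result.

The compounds shown leave open whether any group on this nitrogen would give a change beyond the scatter. From the compounds shown here alone, a carboxylic acid or an amine at the end of a longer chain, for example, remains untested in this set.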